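Octyl in Place of Methyl on a Dinitrophenyl Triazole

The compounds below may be only part of what the source reports. "The series", "measured", "known", "first", "only" and "open" are said of these compounds alone.

Three compounds, compound 1 `O=[N+]([O-])c1cc(CSc2nnc(-c3ccc(Br)cc3)n2Cc2ccccc2)cc([N+](=O)[O-])c1`, compound 2 `Cn1c(SCc2ccccc2)nnc1-c1cc([N+](=O)[O-])cc([N+](=O)[O-])c1` and compound 3 `CSc1nnc(-c2cc([N+](=O)[O-])cc([N+](=O)[O-])c2)n1Cc1ccccc1`, were tested in an ADME assay on A-431 cells (Homo sapiens) for cytotoxicity, with a stated time of 48 h; a higher number here means a weaker inhibitor, a lower number a stronger inhibitor. In this assay compound 1 gives > 30000 nM, which is a limit of the assay and not a number. Compound 2 in this assay likewise gives only the limit > 30000 nM. Compound 3 in this assay gives the limit > 30000 nM. For the measured compounds named here, compound 3 thus stands where both of its companions stand, on (the limit of > 30000 nM in this assay, at which 3 of the 3 values shown sit), and no compound so far shows a number. Compound 4 `CCCCCCCCSc1nnc(-c2cc([N+](=O)[O-])cc([N+](=O)[O-])c2)n1Cc1ccccc1` has not been measured; it differs from compound 3 by heptyl in place of hydrogen on a saturated chain carbon bound to a sulfur. With every value a limit, no step can be read, and the step of a number no higher from compound 3 to compound 4 (the limit leaves the size open) that is expected lies within the scatter. Compound 4 is expected to give 30000 nM in this assay, within 8000 nM to 100000 nM, most likely again as a limit.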

Compound 4, half-maximal inhibitory concentration: > 30000 nM
Compound 4 gave a limit, no number; the forecaster's own chance of this, stated with the estimate: 65%; the middle value lies on the limit itself.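

Compound 3 and compound 4 each give only a limit of the assay and not a number, so no new step can be read between them. The compounds shown leave open whether octyl in place of methyl changes anything in this assay beyond that limit.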